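This account rests on a few compounds, and the source may have more. Where it says the series, first, only, none or still open, it means among the compounds named here.

Among the measured compounds shown here, compound 1 `N#Cc1c(N/N=C2/C(=O)NN=C2N)sc2c1CCCC2` gives 94% in a functional assay on Ehrlich cells (Mus musculus) for cytotoxicity, tested at 25 ug/mL (a higher number here means a stronger effect of the compound at the concentration tested, a lower number a weaker effect), the higher of the two numbers measured so far. For the measured compounds named here, compound 2 `CCOC(=O)c1c(N/N=C2/C(=O)NN=C2N)sc2c1CCCC2` gives 60%, and the one measured step, a number 34 percentage points lower from compound 1 to compound 2 (beyond the scatter), concerns a change on the aromatic carbon. Compound 3 `CC1=NNC(=O)/C1=N/Nc1sc2c(c1C#N)CCCC2` differs from compound 1 elsewhere: methyl in place of amino on a carbon with a double bond to nitrogen. Going by the values given here, no measured step touches this carbon, so the only guide is that compound 1 stands high and a single change lowered the number once. A modest drop is therefore expected, a number 16 percentage points lower from compound 1 to compound 3 (beyond the scatter), giving compound 3 an estimated 78%, within 50% to 98%.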

Compound 3, a percentage reported as activity, at one concentration (the size of the read-out at that concentration, not a potency): 29.8%
Compound 3: middle estimate off by 48.2 percentage points, on the high side; the measured number lies below the stated range.
By their numbers in this assay, from the lowest: compound 3; then compound 2; then compound 1.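

In this assay, the carbon carrying the amino group proves to be a second sensitive place in the molecule, as methyl in place of amino gives a number 64.2 percentage points lower from compound 1 to compound 3 (beyond the scatter). This single-atom swap also removes the hydrogen-bond donor and acceptor counted for amino, but no measurement here explains the drop. 

From the compounds shown here alone, whether a hydroxyl, a methylamino group or a longer chain such as ethyl on this carbon would bring the number back towards that of compound 1 remains open. So does whether methyl in place of amino would have a similar effect alongside the ethoxycarbonyl group of compound 2.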